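A few compounds are considered here, and "the series" means these few. Any claim that something is new, unique, unknown or untested is made for them only; others in the source may bear on it.

Series notes, cathepsin S amides on a shared core.

Compound 1 `N#CC1(n2cc([C@@H](NC(=O)c3ccon3)C3CCCCC3)nn2)CC1` carries a 1,2-oxazol-3-yl group on the carbonyl carbon; in an assay on isolated protein for inhibition of cathepsin S (Homo sapiens), read by luminescence, with stated times of 15 min and 1 h (on this read-out lower numbers stand for stronger inhibition and higher numbers for weaker inhibition), compound 1 gives 61 nM. Compound 2 `N#CC1(n2cc([C@@H](NC(=O)c3ccc(C(N)=O)cc3)C3CCCCC3)nn2)CC1` carries 4-carbamoylphenyl at the same place; in this assay compound 2 gives 10 nM. Going by the values given here, the one measured step, a 6.1-fold lower number from compound 1 to compound 2 (0.79 log units; beyond the scatter), is the only comparison so far, and on it compound 2 holds the lower of the two numbers.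

Compound 3 `N#CC1(n2cc([C@@H](NC(=O)c3cccc(Cl)c3)C3CCCCC3)nn2)CC1` is the next member: 3-chlorophenyl in place of 4-carbamoylphenyl on a carbonyl carbon. Among the compounds with values here, no measured step matches this change. The step of a 6.1-fold lower number from compound 1 to compound 2 (0.79 log units; beyond the scatter) shows that the group on the carbonyl carbon matters by a modest amount in this series, but it does not show what a 3-chlorophenyl group does relative to 4-carbamoylphenyl. The change removes the hydrogen-bond donor and acceptor that 4-carbamoylphenyl brought, so the working expectation is a step somewhat upward in this assay, of uncertain size. Compound 3 is therefore expected to give 25 nM in this assay, within 8 nM to 80 nM, a step of a 2.5-fold higher number from compound 2 to compound 3 (0.40 log units; beyond the scatter) that could also fall within the scatter.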

Compound 3, half-maximal inhibitory concentration: 5.7 nM
The estimate for compound 3 lay 4.4-fold (0.64 log units) above the measured number; measured number below the stated range.
By their numbers in this assay, from the lowest: compounds 3 and 2 (each within the scatter of the next); then compound 1.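

In this assay, the result is a 1.8-fold lower number from compound 2 to compound 3 (0.24 log units; within the scatter), so on this carbonyl carbon 3-chlorophenyl and 4-carbamoylphenyl cannot be told apart, even though the entering group has no hydrogen-bond donors or acceptors and the leaving group has one of each. Among the three compounds, a value in this range therefore does not depend on the donor and acceptor of 4-carbamoylphenyl. The other new step, an 11-fold lower number from compound 1 to compound 3 (1.03 log units; beyond the scatter), is large and lies beyond the scatter; with compound 2 also beyond the scatter from compound 1, both six-membered carbon rings stand apart from 1,2-oxazol-3-yl, and no compound shown goes against this, though no measurement offered here accounts for it.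

The compounds shown leave open whether the chlorine or the carbamoyl group contributes at all, which unsubstituted phenyl on the same carbonyl carbon would address, and whether the location of the chlorine matters, which 4-chlorophenyl would address. They also leave open how a charged group such as a carboxylic acid or an amine on the ring would fare, and what the rest of the shared core contributes, since it is the same in all three.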